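Swapping Octyl for an Aryl Amine on a Shared Core

This account rests on a few compounds, and the source may have more. Where it says the series, first, only, none or still open, it means among the compounds named here.

Measured so far:
- compound 1, `CCCCCCCCNc1nc(SCc2ccc(C(F)(F)F)cc2)nc2ccccc12`: 26100 nM
- compound 2, `FC(F)(F)c1ccc(CSc2nc(Nc3ccccc3)c3ccccc3n2)cc1`: 44000 nM
- compound 3, `FC(F)(F)c1ccc(CSc2nc(Nc3ccccc3Cl)c3ccccc3n2)cc1`: a limit, > 50000 nM

All three were tested in a functional assay on MCF7 cells (Homo sapiens) for cytotoxicity, read by MTT assay, with a stated time of 72 h; on this read-out higher numbers stand for weaker inhibition and lower numbers for stronger inhibition. Among the plain numbers, compound 1 has the lowest; compound 2 sits nearest, with a 1.7-fold higher number from compound 1 to compound 2 (0.23 log units; within the scatter), a step inside the scatter. Compound 3 returned only a limit, (the limit of > 50000 nM in this assay, at which 1 of the 3 values shown sits), and not a number. Compound 4, `FC(F)(F)c1ccc(CSc2nc(Nc3cccc(C(F)(F)F)c3)c3ccccc3n2)cc1`, has not yet been measured and differs from compound 1 in one place: 3-(trifluoromethyl)phenyl in place of octyl on a nitrogen on an aromatic ring. Among the compounds with values here, the steps that bear on this change are a 1.7-fold higher number from compound 1 to compound 2 (0.23 log units; within the scatter) and an at least 1.9-fold higher number from compound 1 to compound 3 (0.28 log units; that floor lies within the scatter); both the phenyl and the 2-chlorophenyl replacements of octyl raised the read-out by amounts that stay within the scatter, the 2-chlorophenyl case ending at the limit. The step expected for compound 4 is therefore a small rise, a 1.7-fold higher number from compound 1 to compound 4 (0.24 log units; within the scatter), not clearly beyond the scatter. Compound 4 is estimated at 45000 nM, with a range from 20000 nM to 100000 nM, and a fair chance that only a limit is returned.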

Compound 4, half-maximal inhibitory concentration: 15300 nM
Beside the measured number, compound 4's estimate is 2.9-fold (0.47 log units) above it; measured number outside the range, below it.
By their numbers in this assay, from the lowest: compounds 4, 1 and 2 (each within the scatter of the next, the first and the last beyond it). At a limit, above all of these: compound 3.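

In this assay, within the data shown here, a change on the aryl group at this nitrogen now moves the read-out beyond the scatter, which none of the earlier steps did: adding trifluoromethyl gives a 2.9-fold lower number from compound 2 to compound 4 (0.46 log units; beyond the scatter), and exchanging 2-chlorophenyl for 3-(trifluoromethyl)phenyl gives an at least 3.2-fold lower number from compound 3 to compound 4 (0.51 log units; beyond the scatter). The figure for compound 3 is only a limit: the limit of > 50000 nM in this assay, at which 1 of the 4 values shown sits. Against octyl the picture is different, with a 1.7-fold lower number from compound 1 to compound 4 (0.23 log units; within the scatter), so octylamino and (3-(trifluoromethyl)phenyl)amino cannot be told apart on this read-out.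

The compounds shown do not settle whether the shift belongs to trifluoromethyl itself or to its place on the phenyl ring, and chloro and trifluoromethyl cannot be compared at one place. Also open, on these data alone, is how a methoxy group, a nitrile or a carboxylic acid on that ring, or a longer chain in place of octyl, would read.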